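The compounds below may be only part of what the source reports. "The series", "measured", "known", "first", "only" and "open" are said of these compounds alone.

Measured so far in a functional assay on CCRF-CEM cells (Homo sapiens) for cytotoxicity, read by MTT assay, with a stated time of 72 h (on this read-out lower numbers stand for stronger inhibition of growth and higher numbers for weaker inhibition of growth), are three carbamates. Compound 1 `CCCCOC(=O)Nc1ccc([Se]C#N)cc1` gives 6500 nM. Compound 2 `C=CCOC(=O)Nc1ccc([Se]C#N)cc1` gives 9200 nM. Compound 3 `N#C[Se]c1ccc(NC(=O)Oc2ccccc2)cc1` gives 22900 nM.

On these three numbers compound 2 stands second highest. Its nearest neighbour is compound 1, with a 1.4-fold higher number from compound 1 to compound 2 (0.15 log units; within the scatter); its furthest is compound 3, with a 2.5-fold higher number from compound 2 to compound 3 (0.40 log units; beyond the scatter).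

Compound 4 `N#C[Se]c1ccc(NC(=O)OCc2ccccc2)cc1` differs from compound 2 in a single place: phenyl in place of vinyl on a saturated chain carbon bound to an oxygen next to a carbonyl group. Among the compounds with values here, no measured step exchanges vinyl for phenyl at that saturated carbon. The steps that come closest put phenyl straight onto the oxygen: a 3.5-fold higher number from compound 1 to compound 3 (0.55 log units; beyond the scatter) and a 2.5-fold higher number from compound 2 to compound 3 (0.40 log units; beyond the scatter), both modest and both beyond the scatter. Compound 4 keeps the saturated carbon between the oxygen and the new ring, so those steps bear on it only loosely, and the expectation is a small rise in the number or none beyond the scatter, the estimated step being a 1.3-fold higher number from compound 2 to compound 4 (0.12 log units; within the scatter). In this assay compound 4 is therefore expected to give about 12000 nM, with a range from 5000 nM to 30000 nM.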

Compound 4, concentration for 50% growth inhibition: 23200 nM
Compound 4: the middle estimate sits 1.9-fold (0.29 log units) below what was measured; low and high end bracket the measured number.
By their numbers in this assay, from the lowest: compounds 1 and 2 (each within the scatter of the next); then compounds 3 and 4 (each within the scatter of the next).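

The rise in the number is not confined to phenyl placed straight on the oxygen: on the saturated chain carbon, phenyl in place of vinyl gives a 2.5-fold higher number from compound 2 to compound 4 (0.40 log units; beyond the scatter) and phenyl in place of propyl gives a 3.6-fold higher number from compound 1 to compound 4 (0.55 log units; beyond the scatter) in this assay across these carbamates. Within the data shown here, compound 3 at 22900 nM and compound 4 at 23200 nM lie within the scatter of each other, so the two compounds carrying phenyl stand above the two with open chains, with no compound among the four going against this. Nothing given here accounts for the change.

On these data alone, whether the rise belongs to phenyl as an aromatic ring remains open, since a cyclohexyl group at the same saturated carbon would be needed to tell. As far as these compounds go, how a longer chain carrying the phenyl, or a pyridine ring in its place, would read also remains open.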